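Cytotoxicity of a hexanoic acid amide series: indol-3-yl variant

The source may hold more compounds than are shown below. What is called first, only, known or untested is meant among the compounds shown, and "the series" means these compounds.

Measured compounds:
compound 1 `CC(C)N(Cc1cccc(OCCCCCC(=O)O)c1)C(=O)c1ccc(-c2ccoc2)cc1`: > 26000 nM
compound 2 `CC(C)N(Cc1cccc(OCCCCCC(=O)O)c1)C(=O)c1ccc(-c2ccc3cc[nH]c3c2)cc1`: > 26000 nM
compound 3 `CC(C)N(Cc1cccc(OCCCCCC(=O)O)c1)C(=O)c1ccc(-c2cccc(OC(F)(F)F)c2)cc1`: > 26000 nM

In an ADME assay on BJ cells (Homo sapiens) for cytotoxicity, read by CellTiter-Glo and resazurin assay, with a stated time of 72 h (on this read-out higher numbers stand for an effect only at larger amounts of compound and lower numbers for an effect already at smaller amounts), compound 1 gives > 26000 nM, which is a limit of the assay and not a number. Compound 2 likewise gives a limit, > 26000 nM. Compound 3 also sits at a limit, > 26000 nM. All three values therefore rest at the limit of > 26000 nM in this assay, at which 3 of the 3 values shown sit, so compound 1 cannot be placed relative to the others; the steps a step that the two limits leave unreadable from compound 1 to compound 2 and a step that the two limits leave unreadable from compound 1 to compound 3 stay unreadable, as does a step that the two limits leave unreadable from compound 2 to compound 3.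

Compound 4 `CC(C)N(Cc1cccc(OCCCCCC(=O)O)c1)C(=O)c1ccc(-c2c[nH]c3ccccc23)cc1` differs from compound 1 as follows: 1H-indol-3-yl in place of furan-3-yl on an aromatic carbon. The two measured steps that start from compound 1 both replace the furan-3-yl group, as this change does, and neither produced a value that came under the limit. Within the data shown here, no step can be sized, so no shift beyond the scatter is expected; the step that the limit leaves unreadable from compound 1 to compound 4 is an estimate. Compound 4 is expected to give about 40000 nM in this assay, within 20000 nM to 100000 nM, most likely again reported only as a limit.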

Compound 4, half-maximal effective concentration: > 26000 nM
Compound 4 was reported as a limit (the forecaster's own chance of this, stated with the estimate: 85%); the middle value lies beyond the limit too.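

Compound 4 gives a limit and not a number, like compound 1, compound 2 and compound 3, so its steps to these three compounds cannot be read: the limit of > 26000 nM in this assay, at which 4 of the 4 values shown sit.

The compounds shown leave open whether any replacement of furan-3-yl shifts the half-maximal effective concentration in this assay.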